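Swapping methoxy for fluoro on the aryl urea

The source may hold more compounds than are shown below. What is called first, only, known or untested is meant among the compounds shown, and "the series" means these compounds.

Three measured compounds share one core and differ only in the aryl group attached to the urea nitrogen. Compound 1 `Cc1cccc(NC(=O)Nc2nnc(Sc3ncnc4scc(-c5ccncc5)c34)s2)c1` gives 5200 nM in a functional assay on PC-3 cells (Homo sapiens) for antiproliferative activity, read by MTT assay, with a stated time of 48 h; on this read-out lower numbers stand for stronger inhibition and higher numbers for weaker inhibition. Compound 2 `O=C(Nc1cccc(Cl)c1)Nc1nnc(Sc2ncnc3scc(-c4ccncc4)c23)s1` gives 8000 nM in this assay. Compound 3 `COc1ccc(NC(=O)Nc2nnc(Sc3ncnc4scc(-c5ccncc5)c34)s2)cc1` gives 9900 nM in this assay, and its steps from the others, a 1.9-fold higher number from compound 1 to compound 3 (0.28 log units; within the scatter) and a 1.2-fold higher number from compound 2 to compound 3 (0.09 log units; within the scatter), both lie within the scatter, as does a 1.5-fold higher number from compound 1 to compound 2 (0.19 log units; within the scatter). Compound 4 `O=C(Nc1ccc(F)cc1)Nc1nnc(Sc2ncnc3scc(-c4ccncc4)c23)s1` differs from compound 3 by fluoro in place of methoxy on an aromatic carbon. For the measured compounds named here, no measured pair exchanges methoxy for fluoro; the three measured exchanges among aryl substituents all stayed within the scatter, so no shift beyond the scatter is expected in this assay. Compound 4 is therefore expected at 8500 nM, between 3500 nM and 22000 nM, meaning a 1.2-fold lower number from compound 3 to compound 4 (0.07 log units; within the scatter).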

Compound 4, half-maximal inhibitory concentration: 970 nM
Compound 4: the middle estimate sits 8.8-fold (0.94 log units) above what was measured, outside the stated range (below it).
By their numbers in this assay, from the lowest: compound 4; then compounds 1, 2 and 3 (each within the scatter of the next).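

In this assay the aryl group on the urea had seemed not to matter, yet 4-fluorophenyl stands apart from all three other aryl groups (a 10-fold lower number from compound 3 to compound 4 (1.01 log units; beyond the scatter); an 8.2-fold lower number from compound 2 to compound 4 (0.92 log units; beyond the scatter); a 5.4-fold lower number from compound 1 to compound 4 (0.73 log units; beyond the scatter)). Methoxy in compound 3 sits in the same place, para to a large group, so the place alone does not set compound 4 apart. Nothing measured here accounts for the gain. The compounds shown leave open whether fluoro must sit in that place. They also leave open how chloro, methyl or an amine would fare there.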